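Shifting a methyl group on a pyridine amide

The compounds below may be only part of what the source reports. "The series", "measured", "known", "first", "only" and "open" are said of these compounds alone.

Within the data shown here, compound 2 `Cc1cccc(C(=O)N[C@H]2CCC[C@H](NC(=O)c3cccc(Cl)c3)C2)n1` gives 290 nM in a functional assay on HEK293 cells for antagonist activity at metabotropic glutamate receptor 5 (Homo sapiens), read by FLIPR and calcium flux (on this read-out lower numbers stand for stronger inhibition and higher numbers for weaker inhibition), the lowest of the two numbers measured so far; compound 1 `O=C(N[C@H]1CCC[C@H](NC(=O)C2CCCCC2)C1)c1cccc(Cl)c1` gives 857 nM. Among the measured compounds shown here, the single measured step, a 3.0-fold lower number from compound 1 to compound 2 (0.47 log units; beyond the scatter), replaced a cyclohexyl group with a 6-methylpyridin-2-yl group. Compound 3 `Cc1cccnc1C(=O)N[C@H]1CCC[C@H](NC(=O)c2cccc(Cl)c2)C1` differs from compound 2 by 3-methylpyridin-2-yl in place of 6-methylpyridin-2-yl on a carbonyl carbon. For the measured compounds named here, no measured step shows the effect of moving the methyl group within the pyridine ring, so only a small shift within the scatter is expected, a 1.4-fold higher number from compound 2 to compound 3 (0.14 log units; within the scatter). The estimate for compound 3 in this assay is 400 nM, between 150 nM and 1200 nM.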

Compound 3, half-maximal inhibitory concentration: 7840 nM
The estimate for compound 3 lay 20-fold (1.29 log units) below the measured number; the whole stated range lies below it.
By their numbers in this assay, from the lowest: compound 2; then compound 1; then compound 3.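

The place on the carbonyl carbon proves sensitive to where the methyl sits on the pyridine: with the same atoms joined differently, the change brings a 27-fold higher number from compound 2 to compound 3 (1.43 log units; beyond the scatter) and takes the series from its lowest number to its highest. A pyridine is thus no general gain over cyclohexyl, since 3-methylpyridin-2-yl gives a 9.1-fold higher number from compound 1 to compound 3 (0.96 log units; beyond the scatter) while 6-methylpyridin-2-yl gave a lower number than cyclohexyl. No measurement at hand explains this gap. Still open, as far as these compounds go, is how the unsubstituted pyridin-2-yl group would compare, and whether a 6-ethylpyridin-2-yl or 6-methoxypyridin-2-yl group would keep the number of compound 2.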